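Swapping the fluorophenyl for a methoxyphenyl on the amide

This account rests on a few compounds, and the source may have more. Where it says the series, first, only, none or still open, it means among the compounds named here.

Measured compounds:
- Compound 1, `COc1ccc(C)cc1NC(=O)CSc1nnc(-c2ccoc2C)n1Cc1ccco1`: 2510 nM
- Compound 2, `Cc1occc1-c1nnc(SCC(=O)Nc2cccc(F)c2)n1Cc1ccco1`: > 15800 nM

Of the compounds shown here, two sharing one core have been tested in a functional assay on CHO cells for antagonist activity at Orexin/Hypocretin receptor type 1 (Homo sapiens), read by FLIPR and calcium flux; on this read-out lower numbers stand for stronger inhibition and higher numbers for weaker inhibition. Compound 1 gives 2510 nM. For compound 2 only a limit of the assay is known, > 15800 nM, so its exact potency is not pinned down; it sits at the limit of > 15800 nM in this assay, at which 1 of the 2 values shown sits. Among the measured compounds shown here, the one measured step, an at least 6.2-fold higher number from compound 1 to compound 2 (0.79 log units; beyond the scatter), shows that 3-fluorophenyl in place of 2-methoxy-5-methylphenyl on an amide-type nitrogen weakens inhibition.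

Compound 3, `COc1ccccc1NC(=O)CSc1nnc(-c2ccoc2C)n1Cc1ccco1`, is not yet measured. Its change from compound 2 is 2-methoxyphenyl in place of 3-fluorophenyl on an amide-type nitrogen. This largely reverses the measured step, since 2-methoxyphenyl keeps the methoxy of compound 1 but not its methyl. Compound 3 is therefore expected to regain much of the potency seen for compound 1, giving a step of about an at least 3.5-fold lower number from compound 2 to compound 3 (0.54 log units; beyond the scatter) toward stronger inhibition, though the limit on compound 2 leaves its size uncertain. The estimate for compound 3 is 4500 nM, with a range from 1500 nM to 16000 nM.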

Compound 3, inhibition constant: > 15800 nM
Compound 3 ended at the assay's limit (the forecaster's own chance of this, stated with the estimate: 35%); middle value at least 3.5-fold (0.54 log units) from the limit.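

In this assay, hydrogen in place of methyl on an aromatic carbon gives an at least 6.2-fold higher number from compound 1 to compound 3 (0.79 log units; beyond the scatter), so this single change shows that the methoxy on its own does not keep the inhibition of compound 1. Compound 3 is known only as a limit of the assay, > 15800 nM. The step from compound 2 to compound 3 cannot be read, so 2-methoxyphenyl and 3-fluorophenyl on the amide-type nitrogen cannot be ranked against each other, and compound 1 remains the only one of the three with an exact number: the limit of > 15800 nM in this assay, at which 2 of the 3 values shown sit.

Still open, as far as these compounds go, is whether the methyl helps only together with the methoxy, and whether an ethyl or a chlorine in the place of that methyl would match or improve on compound 1. Also open, from the compounds shown here alone, is how far compound 2 and compound 3 truly lie from compound 1, and what a carboxylic acid or an amine on the aromatic ring of the amide would do to inhibition.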